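Swapping the aryl on silicon for cyclohexyl

This account rests on a few compounds, and the source may have more. Where it says the series, first, only, none or still open, it means among the compounds named here.

Measured so far:
- compound 1, `CCN(C/C=C/C#CC(C)(C)C)Cc1cccc(OC[Si](C)(C)c2ccc(Cl)cc2)c1`: 400 nM
- compound 2, `CCN(C/C=C/C#CC(C)(C)C)Cc1cccc(OC[Si](C)(C)c2ccc(OC)cc2)c1`: 870 nM
- compound 3, `CCN(C/C=C/C#CC(C)(C)C)Cc1cccc(OC[Si](C)(C)c2ccc(C=O)cc2)c1`: 100 nM

All three share one core and differ only in the group on the silicon. In a functional assay on liver (Sus scrofa) for inhibition of squalene monooxygenase (Homo sapiens), using microsomes (a lower number here means a stronger inhibitor, a higher number a weaker inhibitor), compound 3 gives the lowest of the three numbers; its nearest neighbour is compound 1, at a 4.0-fold lower number from compound 1 to compound 3 (0.60 log units; beyond the scatter), and compound 2 lies furthest, at an 8.7-fold lower number from compound 2 to compound 3 (0.94 log units; beyond the scatter). Compound 4, `CCN(C/C=C/C#CC(C)(C)C)Cc1cccc(OC[Si](C)(C)C2CCCCC2)c1`, is not yet measured. It differs from compound 3 in one place: cyclohexyl in place of 4-formylphenyl on a silicon.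

Among the measured compounds shown here, none of the measured steps swaps the whole aromatic ring for a saturated one; each only exchanges the single group on that ring, as in a 2.2-fold higher number from compound 1 to compound 2 (0.34 log units; beyond the scatter). Those steps show that the number moves by modest amounts whenever this part of the molecule is altered, and that every alternative to formyl gave a higher number. A rise is therefore expected for compound 4, estimated at a 5.0-fold higher number from compound 3 to compound 4 (0.70 log units; beyond the scatter). Compound 4 is expected to give 500 nM, within the range 150 nM to 1800 nM.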

Compound 4, half-maximal inhibitory concentration: 20000 nM
The estimate for compound 4 lay 40-fold (1.60 log units) below the measured number; the whole stated range lies below it.
By their numbers in this assay, from the lowest: compound 3; then compound 1; then compound 2; then compound 4.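

In this assay, replacing the whole aromatic ring on the silicon with cyclohexyl gives a 200-fold higher number from compound 3 to compound 4 (2.30 log units; beyond the scatter), far larger than the biggest exchange of a group on that ring, an 8.7-fold lower number from compound 2 to compound 3 (0.94 log units; beyond the scatter). The rise is also large from the other two aryl compounds, with a 50-fold higher number from compound 1 to compound 4 (1.70 log units; beyond the scatter) and a 23-fold higher number from compound 2 to compound 4 (1.36 log units; beyond the scatter), so in this set it does not depend on which group the aromatic ring carried. This position therefore tolerates changes to the group on the aromatic ring far better than loss of the ring itself, but no available evidence explains the rise.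

Cyclohexyl differs from each aryl group in both the ring and the group on it, so these compounds do not separate those two changes. Plain phenyl on the silicon would help to separate them, and 4-formylcyclohexyl would show whether formyl still lowers the number on a saturated ring.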